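Moving the Ethynyl Group on the Sulfonyl Phenyl Ring

The source may report more compounds than this note shows. Statements on the series, on what has been measured and on what is new or still open speak of the compounds shown alone.

The measured compounds in a functional assay on A-375 cells (Homo sapiens) for antiproliferative activity, read by trypan blue exclusion, with a stated time of 48 h, tested at 10 uM (on this read-out higher numbers stand for a weaker effect at the one concentration tested and lower numbers for a stronger effect), are these.
Compound 1, `CCCCCCC#Cc1ccc(S(=O)(=O)Nc2cccc(-c3csc(NC(C)=O)n3)c2)cc1`, gives 5.8%.
Compound 2, `CC(=O)Nc1nc(-c2cccc(NS(=O)(=O)c3ccc(C#C[Si](C)(C)C)cc3)c2)cs1`, gives a value that is a limit of the assay, < 1%.
Compound 3, `C#Cc1ccc(S(=O)(=O)Nc2cccc(-c3csc(NC(C)=O)n3)c2)cc1`, gives 1.2%.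

Compound 3 has the lowest of the two numbers that are numbers; its nearest neighbour is compound 1, and the step of a number 4.6 percentage points lower from compound 1 to compound 3 (within the scatter) lies within the scatter. One of the three values is a limit, as the line the limit of < 1% in this assay, at which 1 of the 3 values shown sits, records.

Compound 4, `C#Cc1cccc(S(=O)(=O)Nc2cccc(-c3csc(NC(C)=O)n3)c2)c1`, differs from compound 3 by 3-ethynylphenyl in place of 4-ethynylphenyl on a sulfonyl sulfur. Every measured step in this assay alters only the group on the triple-bonded carbon: a number at least 4.8 percentage points lower from compound 1 to compound 2 (that floor lies within the scatter), a number 4.6 percentage points lower from compound 1 to compound 3 (within the scatter) and a number at least 0.2 percentage points higher from compound 2 to compound 3 (that floor lies within the scatter), each within the scatter. Going by the values given here, none moves the ethynyl group to another position on the ring, so no measured step bears directly on the change from compound 3 to compound 4; the shared core with its acetamido-thiazole and sulfonamide is kept in all four compounds.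

Among the compounds with values here, with no step among the three measured compounds exceeding the scatter, compound 4 is expected to show no change beyond the scatter, a step of a number 1.8 percentage points higher from compound 3 to compound 4 (within the scatter). Compound 4 is therefore estimated at 3%, with a range from 0.5% to 12%.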

Compound 4, a percentage reported as activity, at one concentration (the size of the read-out at that concentration, not a potency): 18.6%
The estimate for compound 4 lay 15.6 percentage points below the measured number; the whole stated range lies below it.
By their numbers in this assay, from the lowest: compounds 3 and 1 (each within the scatter of the next); then compound 4. At a limit, below all of these: compound 2.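

In this assay, the exchange of 4-ethynylphenyl for 3-ethynylphenyl on the sulfonyl sulfur gives a number 17.4 percentage points higher from compound 3 to compound 4 (beyond the scatter), the only step shown that lies beyond the scatter, and it points to a weaker effect at the one concentration tested. The two compounds have the same atoms, joined differently, so this step shows that the place of the ethynyl group on this ring can register on this read-out, which the earlier changes to the group on the triple-bonded carbon did not show. Nothing given here accounts for the size or direction of this step.

What the compounds shown leave open is whether hexyl on the triple-bonded carbon would give the same result with 3-ethynylphenyl as with 4-ethynylphenyl, since only one compound here carries the 3-ethynylphenyl group, and a reading at one concentration is not a potency. Going by these compounds, it also remains open whether a nitrile or an amine in place of the ethynyl group would respond to the same change of position on this ring.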